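A few compounds are considered here, and "the series" means these few. Any claim that something is new, unique, unknown or untested is made for them only; others in the source may bear on it.

In a physicochemical assay for lipophilicity (on this read-out higher numbers stand for higher lipophilicity and lower numbers for lower lipophilicity), three compounds sharing one core have been measured so far. Compound 1 `OC(CC1CCCCN1)c1ccnc2ccccc12`, with hydrogen on the aromatic carbon that varies, gives 0.05. Compound 2 `Cc1ccc(Oc2cc(C(O)CC3CCCCN3)c3ccccc3n2)cc1`, with 4-methylphenoxy there, gives 2.69. Compound 3 `CC(C)c1cc(C(O)CC2CCCCN2)c2ccccc2n1`, with isopropyl there, gives 1.58, which is the second highest of the three numbers and clearly separated from both others.

Compound 4 `CC(C)(C)c1cc(C(O)CC2CCCCN2)c2ccccc2n1` differs from compound 3 in a single place: methyl in place of hydrogen on a saturated chain carbon bound to an aromatic carbon and two saturated chain carbons. In words, this is methyl in place of hydrogen on a saturated chain carbon bound to an aromatic carbon and two saturated chain carbons, so isopropyl becomes tert-butyl.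

Among the measured compounds shown here, no measured step makes exactly this change. The closest is isopropyl in place of hydrogen, with a number 1.53 log units higher from compound 1 to compound 3 (beyond the scatter). The step for 4-methylphenoxy in place of hydrogen, a number 2.64 log units higher from compound 1 to compound 2 (beyond the scatter), points the same way. Both steps are large, but each puts a whole group onto the core, whereas here only one methyl is added to a group already present. A rise in this assay is therefore expected, though a much smaller one, and it may end up not far beyond the scatter. The estimated change is a number 0.42 log units higher from compound 3 to compound 4 (beyond the scatter). Compound 4 is expected at 2, within an estimated range of 1.7 to 2.4.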

Compound 4, partition coefficient: 2.03
For compound 4 the middle estimate is 0.03 log units below the measured one, and the stated range covers the measured number.
By their numbers in this assay, from the lowest: compound 1; then compound 3; then compound 4; then compound 2.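

The earlier compounds shown here showed only whole groups replacing hydrogen on the aromatic carbon, whereas here a group already in place is extended: in this assay turning isopropyl into tert-butyl gives a number 0.45 log units higher from compound 3 to compound 4 (beyond the scatter) and so a single added methyl on the saturated chain carbon is enough to leave the scatter behind. Set against the plain core, tert-butyl gives a number 1.98 log units higher from compound 1 to compound 4 (beyond the scatter) and this large step contrasts with the modest one for the added methyl. Tert-butyl still does not reach the aryl ether, as replacing 4-methylphenoxy with it gives a number 0.66 log units lower from compound 2 to compound 4 (beyond the scatter) and the four groups now run in a clear order from hydrogen through isopropyl and tert-butyl to 4-methylphenoxy.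

On these data alone, whether a longer chain, an amine or a carboxylic acid on this aromatic carbon would fit into that order remains open, and so does the size of the step for a single methyl added at any other place on the shared core. Nothing given here accounts for the sizes of these steps.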